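The source may hold more compounds than are shown below. What is called first, only, known or untested is meant among the compounds shown, and "the series" means these compounds.

Compound 2 `CC1=CC[C@H](C(C)(C)NC(=S)N/N=C/c2cccc(Cl)c2)CC1` is the reference point here. In a functional assay on MCF7 cells (Homo sapiens) for inhibition, read by sulforhodamine B assay, with a stated time of 48 h (a lower number here means a stronger inhibitor of growth, a higher number a weaker inhibitor of growth), compound 2 gives 8000 nM, the lowest of the two numbers at hand; its nearest neighbour is compound 1 `CC1=CC[C@H](C(C)(C)NC(=S)N/N=C/c2ccccc2)CC1`, which in this assay gives 8400 nM, and the step of a 1.1-fold lower number from compound 1 to compound 2 (0.02 log units; within the scatter) is within the scatter, so the two cannot be told apart. The next compound, compound 3 `CC1=CC[C@H](C(C)(C)NC(=S)N/N=C/c2cccc([N+](=O)[O-])c2)CC1`, differs from compound 2 in one place: nitro in place of chloro on an aromatic carbon. Among the measured compounds shown here, the only measured step that bears on this change is the one from hydrogen to chloro at the same aromatic carbon, a 1.1-fold lower number from compound 1 to compound 2 (0.02 log units; within the scatter), which did not move the number beyond the scatter. On that basis the exchange of chloro for nitro is expected to give at most a small step, no change at the digits printed from compound 2 to compound 3 (within the scatter), in no particular direction. Compound 3 is therefore estimated at 8000 nM, with a range from 4000 nM to 16000 nM.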

Compound 3, concentration for 50% growth inhibition: > 100000 nM
Compound 3: a limit, no number (the forecaster's own chance of this, stated with the estimate: 5%); at least 12-fold (1.09 log units) between middle value and limit.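

The earlier pair, where hydrogen and chloro could not be told apart, gave no sign that this aromatic carbon, meta to a large group, was sensitive to what it carries, but the nitro group changes that, with an at least 12-fold higher number from compound 2 to compound 3 (1.09 log units; beyond the scatter) and an at least 11-fold higher number from compound 1 to compound 3 (1.07 log units; beyond the scatter). In this assay compound 3 gives > 100000 nM, which is a limit of the assay and not a number. The true size of both steps is therefore unknown, and they stand only as minimum sizes: the limit of > 100000 nM in this assay, at which 1 of the 3 values shown sits.

Going by these compounds, it remains open whether the loss of growth inhibition belongs to nitro alone or would also follow with an amine, a methoxy group or a nitrile at this carbon. On these data alone, it is also open whether nitro on another carbon of the ring would give the same result.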